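The source may hold more compounds than are shown below. What is called first, only, known or untested is meant among the compounds shown, and "the series" means these compounds.

In a functional assay on MDA-MB-231 cells (Homo sapiens) for antiproliferative activity, read by MTT assay, with a stated time of 72 h (a lower number here means a stronger inhibitor, a higher number a weaker inhibitor), compound 1 (`NC1=NC2(CCSCC2)N(OCCCOc2ccc(Cl)c(Cl)c2)C(N)=N1`) gives 10 nM and compound 2 (`CC(C)(C)c1ccc(OCCCON2C(N)=NC(N)=NC23CCSCC3)cc1`) gives 1 nM on the numbers available. Compound 3 (`NC1=NC2(CCOCC2)N(OCCCOc2ccc(F)cc2)C(N)=N1`) stands apart from both, since its entry reads "not determined" (no result reported) and it therefore has no place on that scale. Whether it would fall near the other two, or well away from them, is simply unknown.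

Compound 4 (`NC1=NC2(CCOCC2)N(OCCCOc2cccc(Cl)c2)C(N)=N1`) is the unmeasured neighbour of compound 3. The structural change is 3-chlorophenyl in place of 4-fluorophenyl on an oxygen on a saturated carbon and it amounts to 3-chlorophenyl in place of 4-fluorophenyl on an oxygen on a saturated carbon, while the rest of the molecule stays as it is.

Going by the values given here, with no number for compound 3, the step has no measured starting point, and no measured pair in this small set shows what such a swap does. No step beyond the scatter is expected, and no direction can be argued for it. The nearest guide is compound 1 at 10 nM and compound 2 at 1 nM in a set where the core of compound 3 differs from theirs, so a wide range is warranted. In this assay compound 4 is estimated at 20 nM (expected range 3 nM to 150 nM).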

Compound 4, half-maximal inhibitory concentration: 1020 nM
Compound 4: the middle estimate sits 51-fold (1.71 log units) below what was measured, outside the stated range (above it).
By their numbers in this assay, from the lowest: compound 2; then compound 1; then compound 4.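

In this assay compound 4 gives 1020 nM, but compound 3 has no number to set against it, so no step can be read between the two. No supporting evidence bears on this result. Going by these compounds, what putting 3-chlorophenyl in place of 4-fluorophenyl does to the value in this assay remains open.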